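This account rests on a few compounds, and the source may have more. Where it says the series, first, only, none or still open, it means among the compounds named here.

Of the compounds shown here, three built on one shared core have been tested so far: compound 1 `CCNC(=O)/C=C/[C@H]1C[C@@H](O)[C@@H](O)C1`, compound 2 `O=C(/C=C/[C@H]1C[C@@H](O)[C@@H](O)C1)NC1CC1` and compound 3 `O=C(/C=C/[C@H]1C[C@@H](O)[C@@H](O)C1)Nc1ccc(Cl)cc1`. In an ADME assay on S2 cells (Drosophila melanogaster) for cytotoxicity, read by MTT assay (a higher number here means that more compound is needed for the effect, a lower number that less compound is needed), compound 1 gives only a limit of the assay, > 250000 nM. Compound 2 likewise gives only a limit in this assay, > 250000 nM. Because both are limits, the step that the two limits leave unreadable from compound 1 to compound 2 cannot be read as a number. Compound 3 also gives only a limit in this assay, > 180000 nM. For the measured compounds named here, compound 3 thus stands where every measured value so far stands, at a limit rather than a number. Two of the three values sit at one limit: the limit of > 250000 nM in this assay, at which 2 of the 3 values shown sit. The remaining value sits at another: the limit of > 180000 nM in this assay, at which 1 of the 3 values shown sits.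

The next compound is compound 4 `CC(=O)c1ccc(NC(=O)/C=C/[C@H]2C[C@@H](O)[C@@H](O)C2)cc1`. It differs from compound 3 by acetyl in place of chloro on an aromatic carbon. Going by the values given here, no measured step bears on this change, and the single step that exists is unreadable, so there is nothing to suggest a change beyond the scatter in this assay. The expected step that the limit leaves unreadable from compound 3 to compound 4 is therefore no larger than the scatter. Compound 4 is expected to give about 250000 nM, with a range from 100000 nM to 600000 nM, and most likely only as a limit again.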

Compound 4, half-maximal effective concentration: > 180000 nM
Compound 4 was reported as a limit (the forecaster's own chance of this, stated with the estimate: 85%); the middle value is on the limit's open side.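

Compound 3 and compound 4 both give only a limit of the assay and not a number, so the change to acetyl in place of chloro yields no step that can be read: the limit of > 180000 nM in this assay, at which 2 of the 4 values shown sit.

The compounds shown leave open how much of any of them is needed for the effect in this assay, and whether any change on the shared core alters that amount.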